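The source may hold more compounds than are shown below. What is called first, only, known or untested is meant among the compounds shown, and "the series" means these compounds.

Compound 1 `CC1CCN(c2c(S(=O)(=O)c3cccc(Cl)c3)cnc3cc(Cl)ccc23)CC1` gives 92% in an assay on isolated protein for displacement of a labelled ligand from metabotropic glutamate receptor 5 (Homo sapiens), with a stated time of 60 min, tested at 1 uM; on this read-out lower numbers stand for less inhibition and higher numbers for more inhibition at the one concentration tested (going by the name of the read-out). Compound 2 `COc1cccc(S(=O)(=O)c2cnc3cc(Cl)ccc3c2N2CCC(C)CC2)c1` gives 93% in this assay.

Compound 2 has the larger of the two numbers, but only by a number 1 percentage points higher from compound 1 to compound 2 (within the scatter), so compound 1 and compound 2 lie within the usual scatter of each other, and the two numbers count as level. That step exchanged methoxy for chloro on an aromatic carbon and left the read-out unchanged within the scatter.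

Compound 3 `Cc1ccc(S(=O)(=O)c2cnc3cc(Cl)ccc3c2N2CCC(C)CC2)cc1Cl` has not been measured. It differs from compound 2 as follows: 3-chloro-4-methylphenyl in place of 3-methoxyphenyl on a sulfonyl sulfur. Among the measured compounds shown here, the only measured step that bears on this change is the one from compound 1 to compound 2, which was a number 1 percentage points higher from compound 1 to compound 2 (within the scatter) and concerned a chloro against a methoxy on the same aromatic ring. For the measured compounds named here, that step was within the scatter, and no measured step covers the methyl that enters with the 3-chloro-4-methylphenyl group. The expectation for this assay is therefore a step of no size beyond the scatter, about a number 5 percentage points lower from compound 2 to compound 3 (within the scatter) from compound 2 to compound 3. Compound 3 is thus estimated to give 88%, within a range from 70% to 98%.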

Compound 3, a percentage reported as inhibition, at one concentration (the size of the read-out at that concentration, not a potency): 89%
Estimate against measurement, compound 3: 1 percentage points below, and the stated range covers the measured number.
By their numbers in this assay, from the lowest: compounds 3, 1 and 2 (each within the scatter of the next).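

Adding a methyl on an aromatic carbon, a change no earlier pair covered, gave a number 3 percentage points lower from compound 1 to compound 3 (within the scatter) in this assay, so this position carried the extra group without a change beyond the scatter. The full exchange on the sulfonyl sulfur, 3-chloro-4-methylphenyl in place of 3-methoxyphenyl, gave a number 4 percentage points lower from compound 2 to compound 3 (within the scatter), even though the leaving group counts a hydrogen-bond acceptor and the entering group none; compound 1, compound 2 and compound 3 therefore stand level, and the aromatic group on the sulfonyl sulfur has now been varied by more than a single chloro-to-methoxy exchange without the number moving beyond the scatter. No measurement given here explains why these changes leave the number level.

Since the read-out was taken at one concentration and is not a potency, these compounds leave open whether real differences in potency lie behind the level numbers. They also leave open whether a much different group on the same aromatic ring, such as a carboxylic acid, an amine or a longer alkyl chain, would keep the number where it stands.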